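Acetylated glycosyl triazole series: indole and oxindole variants

A few compounds are considered here, and "the series" means these few. Any claim that something is new, unique, unknown or untested is made for them only; others in the source may bear on it.

Measured compounds:
compound 1, `COc1ccc2c(c1)c(/C=N/O)cn2Cc1cn([C@@H]2O[C@H](COC(C)=O)[C@@H](OC(C)=O)[C@H](OC(C)=O)[C@H]2OC(C)=O)nn1`, in a functional assay on MCF7 cells (Homo sapiens) for cytotoxicity, read by sulforhodamine B assay, with a stated time of 48 h (on this read-out higher numbers stand for weaker inhibition and lower numbers for stronger inhibition), compound 1 gives 51000 nM
compound 2, `CC(=O)OC[C@H]1O[C@@H](n2cc(Cn3cc([N+](=O)[O-])c4ccccc43)nn2)[C@H](OC(C)=O)[C@@H](OC(C)=O)[C@@H]1OC(C)=O`, in this assay compound 2 gives > 200000 nM, which is a limit of the assay and not a number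
compound 3, `COc1ccc(/C=C2\C(=O)N(Cc3cn([C@@H]4O[C@H](COC(C)=O)[C@@H](OC(C)=O)[C@H](OC(C)=O)[C@H]4OC(C)=O)nn3)c3ccccc32)cc1OC`, in this assay compound 3 gives 23500 nM

Compound 3 holds the lower of the two numbers in this assay; compound 1 sits higher, and that gap lies beyond the usual scatter. Compound 2 contributes only a limit, so no order can be read between it and the others beyond that.

The next compound in the series is compound 4, `CC(=O)OC[C@H]1O[C@@H](n2cc(CN3C(=O)/C(=C\c4ccc5ccccc5c4)c4ccccc43)nn2)[C@H](OC(C)=O)[C@@H](OC(C)=O)[C@@H]1OC(C)=O`. It differs from compound 3 in one place: naphthalen-2-yl in place of 3,4-dimethoxyphenyl on a double-bonded chain carbon bound to a double-bonded ring carbon. For the measured compounds named here, no measured pair changes this position, so the size of the step from compound 3 to compound 4 in this assay cannot be read from measured data. The change swaps one aromatic substituent for another of the same heavy-atom count at the same place, with no charge introduced, so a step of modest size is expected, direction uncertain, and it may well fall within the scatter. Compound 4 is therefore estimated at 20000 nM, with a range from 8000 nM to 60000 nM, which means an expected step of a 1.2-fold lower number from compound 3 to compound 4 (0.07 log units; within the scatter).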

Compound 4, half-maximal inhibitory concentration: 46500 nM
The estimate for compound 4 lay 2.3-fold (0.37 log units) below the measured number; measured number inside the range.
By their numbers in this assay, from the lowest: compounds 3, 4 and 1 (each within the scatter of the next, the first and the last beyond it). At a limit, above all of these: compound 2.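

In this assay, for the compounds shown here, replacing 3,4-dimethoxyphenyl with naphthalen-2-yl on a double-bonded chain carbon bound to a double-bonded ring carbon gives a 2.0-fold higher number from compound 3 to compound 4 (0.30 log units; within the scatter), the first measured step at this place. For this pair, exchanging one six-membered aromatic ring of carbon only that bears the two methoxy groups and their hydrogen-bond acceptors for two such rings without any acceptor does not separate the compounds on this read-out, although the heavy-atom count stays the same and the two groups differ in ring count and oxygen content. No measurement at hand bears on a cause for this step.

Open, going by these compounds, is whether a group of another kind at this place, such as a cyclohexyl ring, a dimethylamino-substituted phenyl or a carboxylic acid on the phenyl ring, would give a step beyond the scatter, and whether a single methoxy group would behave like the 3,4-dimethoxyphenyl group. Going by these compounds alone, no step involving compound 1 or compound 2 can be read, since each differs from the others in more than one place.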